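The source may hold more compounds than are shown below. What is called first, only, known or untested is meant among the compounds shown, and "the series" means these compounds.

Measured so far in an assay for inhibition of NAD-dependent protein deacylase sirtuin-6 (Homo sapiens), read by HPLC, with stated times of 15 min and 1 h, tested at 333 uM; a higher number here means more inhibition at the concentration tested (going by the name of the read-out), a lower number less inhibition:

- compound 1 `CCCCCCNC(=O)CCCSC[C@H](NC(=O)OCc1ccccc1)C(=O)Nc1ccccc1`: "not active" (no number reported)
- compound 2 `NC(=O)CCCSC[C@H](NC(=O)OCc1ccccc1)C(=O)Nc1ccccc1`: 11%
- compound 3 `CCCCCCCCNC(=O)CCCSC[C@H](NC(=O)OCc1ccccc1)C(=O)Nc1ccccc1`: "not active" (no number reported)

Compound 3 stands without a single number in this assay; it is reported as not active, and compound 1 is a second entry of that kind. The only numbered result in the set is that of compound 2, which in this assay gives 11%, a weak read-out at the concentration tested. For the measured compounds named here, no step between two measured compounds is available, so nothing can be said about the size of any difference within the set beyond what the single number and the two unnumbered entries show.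

Compound 4 `O=C(O)CNC(=O)CCCSC[C@H](NC(=O)OCc1ccccc1)C(=O)Nc1ccccc1` differs from compound 3 as follows: carboxy in place of heptyl on a saturated chain carbon bound to an amide-type nitrogen. The octylcarbamoyl end of compound 3 becomes a (carboxymethyl)carbamoyl end. In this assay any step from compound 3 is expected to be small, staying within the scatter, with low read-outs on both sides; the carboxy-bearing chain end is not expected to move the number far from that of compound 2. Compound 4 is therefore estimated at 10%, within 0% to 25%, with a sizeable chance that only a not-active entry is reported.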

Compound 4, a percentage reported as inhibition, at one concentration (the size of the read-out at that concentration, not a potency): 53%
The estimate for compound 4 lay 43 percentage points below the measured number; measured number above the stated range.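

In this assay, the amide-type nitrogen at the chain end is a position where the read-out can move: carboxymethyl in place of hydrogen gives a number 42 percentage points higher from compound 2 to compound 4 (beyond the scatter). Substitution on this nitrogen does not by itself give a high read-out, since compound 3, with octyl there, is reported as "not active" (no number reported), whereas compound 4 gives 53%; steps from the two unnumbered entries cannot be read. No measurement shown here accounts for the rise at compound 4.

On these data alone, it remains open whether the carboxylic acid itself is required, or whether its methyl ester or primary amide would give a similar read-out. Also open, as far as these compounds go, is how a longer chain ending in a carboxylic acid, or a chain ending in an amine, would compare with compound 4.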